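Moving a Methoxy Group Around a Phenyl Ring

The source may hold more compounds than are shown below. What is called first, only, known or untested is meant among the compounds shown, and "the series" means these compounds.

Compound 3 `COc1cccc(-c2cc(COC(Cc3cn(C4CCN(Cc5ccc([N+](=O)[O-])cc5)CC4)nn3)c3ccc(Br)cc3)on2)c1` belongs to a set of three compounds with a shared core tested in a functional assay on Huh-7 cells (Homo sapiens) for cytotoxicity, with a stated time of 48 h; a higher number here means a weaker inhibitor, a lower number a stronger inhibitor. Compound 3 gives 5000 nM, the highest of the three numbers; compound 1 `O=[N+]([O-])c1ccc(CN2CCC(n3cc(CC(OCc4cc(-c5ccc(F)cc5)no4)c4ccc(Br)cc4)nn3)CC2)cc1` gives 2000 nM and compound 2 `COc1ccc(-c2cc(COC(Cc3cn(C4CCN(Cc5ccc([N+](=O)[O-])cc5)CC4)nn3)c3ccc(Br)cc3)on2)cc1` gives 2000 nM. The steps of a 2.5-fold higher number from compound 1 to compound 3 (0.40 log units; beyond the scatter) and a 2.5-fold higher number from compound 2 to compound 3 (0.40 log units; beyond the scatter) lie beyond the scatter, whereas no change at the digits printed from compound 1 to compound 2 (within the scatter). Compound 4 `COc1ccccc1-c1cc(COC(Cc2cn(C3CCN(Cc4ccc([N+](=O)[O-])cc4)CC3)nn2)c2ccc(Br)cc2)on1` differs from compound 3 in one place: 2-methoxyphenyl in place of 3-methoxyphenyl on an aromatic carbon. For the measured compounds named here, no measured step places a methoxy group at this position, so the only guide is that shifting it between the other two positions changed the number modestly. A modest step in either direction, or none beyond the scatter, is therefore expected, amounting to a 1.4-fold lower number from compound 3 to compound 4 (0.15 log units; within the scatter). Compound 4 is expected to give 3500 nM, within 1500 nM to 8000 nM.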

Compound 4, half-maximal inhibitory concentration: 5000 nM
Estimate against measurement, compound 4: 1.4-fold (0.15 log units) below, and the stated range covers the measured number.
By their numbers in this assay, from the lowest: compounds 1 and 2 (each within the scatter of the next); then compounds 3 and 4 (each within the scatter of the next).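

In this assay, moving the methoxy group from 3-methoxyphenyl to 2-methoxyphenyl gives a result within the scatter (no change at the digits printed from compound 3 to compound 4 (within the scatter)). Replacing 4-methoxyphenyl with 2-methoxyphenyl gives a modest step (a 2.5-fold higher number from compound 2 to compound 4 (0.40 log units; beyond the scatter)), as does replacing 4-fluorophenyl with 2-methoxyphenyl (a 2.5-fold higher number from compound 1 to compound 4 (0.40 log units; beyond the scatter)), so among the three methoxy compounds only the 4-methoxyphenyl compound stands apart. Nothing shown explains this difference. Still open, going by these compounds, is how an amine or a carboxylic acid on this phenyl ring, in place of methoxy, would read in this assay.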